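Piperazine substituent swap: acyl group restores inhibition?

This account rests on a few compounds, and the source may have more. Where it says the series, first, only, none or still open, it means among the compounds named here.

Measured compounds in a functional assay on cells (T-cell, Homo sapiens) for inhibition; on this read-out higher numbers stand for weaker inhibition and lower numbers for stronger inhibition:
Compound 1, `COc1ccc(-c2cnc3nc(N)nc(N4CCN(C(=O)NCc5ccccc5)CC4)c3n2)cc1OC`, gives 18 nM.
Compound 2, `COc1ccc(-c2cnc3nc(N)nc(N4CCN(c5ccc(C)cc5)CC4)c3n2)cc1OC`, gives 300 nM.
Compound 3, `COc1ccc(-c2cnc3nc(N)nc(N4CCN(Cc5c(Cl)cccc5Cl)CC4)c3n2)cc1OC`, gives 7600 nM.

Compound 3 sits at the weak end of this set: the step of a 420-fold higher number from compound 1 to compound 3 (2.63 log units; beyond the scatter) and the step of a 25-fold higher number from compound 2 to compound 3 (1.40 log units; beyond the scatter) are both large and both beyond the scatter. Compound 4, `COc1ccc(-c2cnc3nc(N)nc(N4CCN(C(=O)COc5ccc(Cl)cc5)CC4)c3n2)cc1OC`, differs from compound 3 by ((4-chlorophenoxy)methyl)carbonyl in place of 2,6-dichlorobenzyl on an amine nitrogen in a ring. The step that bears most on it is a 420-fold higher number from compound 1 to compound 3 (2.63 log units; beyond the scatter), which shows that exchanging a carbonyl-bearing group for the 2,6-dichlorobenzyl group on the ring nitrogen cost a great deal; compound 4 reverses that kind of exchange, so a large improvement is expected, close to the level of compound 1. Compound 4 is therefore estimated at 50 nM, within 10 nM to 300 nM, an expected step of a 150-fold lower number from compound 3 to compound 4 (2.18 log units; beyond the scatter).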

Compound 4, half-maximal inhibitory concentration: 0.5 nM
Compound 4: middle estimate off by 100-fold (2.00 log units), on the high side; measured number outside the range, below it.
By their numbers in this assay, from the lowest: compound 4; then compound 1; then compound 2; then compound 3.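

In this assay, the step of a 36-fold lower number from compound 1 to compound 4 (1.56 log units; beyond the scatter) shows that the group on the carbonyl carbon matters as well: with the carbonyl kept, (4-chlorophenoxy)methyl in place of benzylamino still gives a large change. The gaps to the two compounds without that carbonyl are wider still, with a 600-fold lower number from compound 2 to compound 4 (2.78 log units; beyond the scatter) and a 15000-fold lower number from compound 3 to compound 4 (4.18 log units; beyond the scatter) on the same read-out. No measurement shown gives a reason for these steps. The compounds shown leave open whether the chlorine or the ether oxygen of the (4-chlorophenoxy)methyl group carries the gain. A plain phenoxymethyl or a simple acetyl group on the same nitrogen would separate these parts.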